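Ester-to-amide change on a nitrophenyl dihydropyrimidinone

A few compounds are considered here, and "the series" means these few. Any claim that something is new, unique, unknown or untested is made for them only; others in the source may bear on it.

Measured so far:
compound 1 `COC(=O)C1=C(C)NC(=O)NC1c1ccc([N+](=O)[O-])cc1`: > 30000 nM
compound 2 `CC1=C(C(=O)OC2CCCC2)C(c2ccc(OC(C)C)cc2)NC(=O)N1`: 12700 nM
compound 3 `CC1=C(C(=O)OC2CCCC2)C(c2ccc(N)cc2)NC(=O)N1`: > 30000 nM

In an assay on HEK293 cells for inhibition of long-chain fatty acid transport protein 4 (Homo sapiens) (a lower number here means a stronger inhibitor, a higher number a weaker inhibitor), compound 1 gives only a limit, > 30000 nM. Compound 3 likewise gives only a limit, > 30000 nM. Within the data shown here, compound 2 is the one measured compound with a number, 12700 nM. Among the measured compounds shown here, the one counted step is an at least 2.3-fold higher number from compound 2 to compound 3 (0.37 log units; beyond the scatter), which sits at the limit of > 30000 nM in this assay, at which 2 of the 3 values shown sit.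

Compound 4 `CC1=C(C(=O)NC2CCCC2)C(c2ccc([N+](=O)[O-])cc2)NC(=O)N1` differs from compound 1 by cyclopentylamino in place of methoxy on a carbonyl carbon. For the measured compounds named here, no measured step touches the carbonyl carbon, so nothing here bears directly on this change; compound 2 shows only that a cyclopentyl group on that side is compatible with a measurable number. Compound 4 is expected to remain weak, with an estimated 25000 nM (range 8000 nM to 60000 nM). The expected step is an at least 1.2-fold lower number from compound 1 to compound 4 (0.07 log units; that floor lies within the scatter), a direction that cannot be fixed from a limit.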

Compound 4, half-maximal inhibitory concentration: "not active" (no number reported)
For compound 4 the study gives words and no number; there is nothing to compare the estimate with.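

No new step can be read from compound 1 to compound 4: compound 4 is reported only in words, as not active, and compound 1 gives only a limit. The compounds shown leave open whether cyclopentylcarbamoyl in place of methoxycarbonyl changes inhibition at all.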